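Reversing the exchange: from compound 2 to compound 3

This account rests on a few compounds, and the source may have more. Where it says the series, first, only, none or still open, it means among the compounds named here.

In a functional assay on PC-3 cells (Homo sapiens) for cytotoxicity, with a stated time of 48 h (on this read-out lower numbers stand for stronger inhibition and higher numbers for weaker inhibition), compound 1 `COc1ccc(-c2cc(COC(Cc3cn(C4CCN(Cc5ccc([N+](=O)[O-])cc5)CC4)nn3)c3ccc(Br)cc3)on2)cc1` gives 3000 nM. Compound 2 `N#Cc1cccc(-c2cc(COC(Cc3cn(C4CCN(Cc5ccc([N+](=O)[O-])cc5)CC4)nn3)c3ccc(Br)cc3)on2)c1` shows in this assay only a limit, > 25000 nM, and therefore sits at the limit of > 25000 nM in this assay, at which 1 of the 2 values shown sits. Compound 3 `COc1ccccc1-c1cc(COC(Cc2cn(C3CCN(Cc4ccc([N+](=O)[O-])cc4)CC3)nn2)c2ccc(Br)cc2)on1` differs from compound 2 by 2-methoxyphenyl in place of 3-cyanophenyl on an aromatic carbon. Among the measured compounds shown here, the single measured step, an at least 8.3-fold higher number from compound 1 to compound 2 (0.92 log units; beyond the scatter), is the same kind of exchange run in reverse, though with 2-methoxyphenyl rather than 4-methoxyphenyl entering, so it bears on it only in part. A lower number is therefore expected for compound 3, an at least 2.7-fold lower number from compound 2 to compound 3 (0.44 log units; beyond the scatter). Compound 3 is estimated at 9000 nM, within 2500 nM to 30000 nM.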

Compound 3, half-maximal inhibitory concentration: > 25000 nM
Compound 3 ended at the assay's limit (the forecaster's own chance of this, stated with the estimate: 35%); at least 2.7-fold (0.44 log units) between middle value and limit.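

In this assay, the methoxy group alone does not keep a measurable value at this place on the five-membered aromatic ring: 2-methoxyphenyl in place of 4-methoxyphenyl gives an at least 8.3-fold higher number from compound 1 to compound 3 (0.92 log units; beyond the scatter). Among the three groups shown here, only 4-methoxyphenyl, in compound 1, gives a number, 3000 nM. The step from compound 2 to compound 3 cannot be read, as each of the two compounds gives only a limit: the limit of > 25000 nM in this assay, at which 2 of the 3 values shown sit.

As far as these compounds go, it remains open whether an amine or a hydroxyl group on the phenyl ring, or ethoxy in place of the methoxy group, would give a measurable value here.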